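The compounds below may be only part of what the source reports. "The series", "measured", "known", "first", "only" and "open" are said of these compounds alone.

In a functional assay on HT-29 cells (Homo sapiens) for inhibition, read by sulforhodamine B assay, with a stated time of 72 h (on this read-out lower numbers stand for stronger inhibition and higher numbers for weaker inhibition), compound 1 (`CCSc1ccc(C2C(O)C(=O)N2c2cc(OC)c(OC)c(OC)c2)cc1`) gives 12 nM and compound 3 (`CCOc1ccc(C2C(O)C(=O)N2c2cc(OC)c(OC)c(OC)c2)cc1`) gives 15 nM while compound 2 (`C=CC1C(=O)N(c2cc(OC)c(OC)c(OC)c2)C1c1ccc(SC)cc1`) gives 113 nM on the same read-out. Compound 3 sits with compound 1 at the low end of these numbers, the two within the scatter of each other, and compound 2 lies well beyond that scatter. Compound 4 (`COc1cc(N2C(=O)C(O)C2c2ccc(SC)cc2)cc(OC)c1OC`) carries methylsulfanyl in place of ethoxy on an aromatic carbon, para to a large group (methylsulfanyl in place of ethoxy on an aromatic carbon). Going by the values given here, one measured step bears on this, ethoxy in place of ethylsulfanyl on an aromatic carbon (a 1.3-fold higher number from compound 1 to compound 3 (0.10 log units; within the scatter)), and it stays within the scatter. No step beyond the scatter is therefore expected in this assay, the estimated step being (a 1.2-fold lower number from compound 3 to compound 4 (0.06 log units; within the scatter)). Compound 4 is expected near 13 nM with an estimated range from 5 nM to 35 nM on this read-out.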

Compound 4, half-maximal inhibitory concentration: 15 nM
Compound 4: middle estimate off by 1.2-fold (0.06 log units), on the low side, within the range that was stated.
By their numbers in this assay, from the lowest: compounds 1, 3 and 4 (each within the scatter of the next); then compound 2.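

In this assay, methylsulfanyl and ethoxy on this aromatic carbon, para to a large group, read alike (no change at the digits printed from compound 3 to compound 4 (within the scatter)), and methylsulfanyl and ethylsulfanyl do too (a 1.3-fold higher number from compound 1 to compound 4 (0.10 log units; within the scatter)). With methylsulfanyl now on both compounds, the gap to compound 2 rests on one place, hydroxy in place of vinyl on a saturated ring carbon (a 7.5-fold lower number from compound 2 to compound 4 (0.88 log units; beyond the scatter)). Nothing available accounts for these results. Still open, as far as these compounds go, is whether an amine or a longer chain such as butoxy on the aromatic carbon would read the same. Also open, from the compounds shown here alone, is how an amine or a methyl in place of the hydroxy would read.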